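Aryl exchange on the benzyl amide: compound 2 to compound 3

A few compounds are considered here, and "the series" means these few. Any claim that something is new, unique, unknown or untested is made for them only; others in the source may bear on it.

Among the compounds with values here, in a functional assay on Jurkat cells (Homo sapiens) (a higher number here means a weaker inhibitor, a lower number a stronger inhibitor), compound 1 (`Cc1ccc(CNC(=O)C(=O)N[C@@H](C)C(=O)N[C@@H](CC(=O)O)C(=O)COc2c(F)c(F)cc(F)c2F)cc1`) gives 50 nM, and compound 2 (`Cc1ccc(C)c(CNC(=O)C(=O)N[C@@H](C)C(=O)N[C@@H](CC(=O)O)C(=O)COc2c(F)c(F)cc(F)c2F)c1`) gives 11 nM, the lowest of the two numbers so far. Compound 3 (`C[C@H](NC(=O)C(=O)NCc1ccc(Cl)cc1Cl)C(=O)N[C@@H](CC(=O)O)C(=O)COc1c(F)c(F)cc(F)c1F`) differs from compound 2 in one place: 2,4-dichlorophenyl in place of 2,5-dimethylphenyl on a saturated chain carbon bound to an amide-type nitrogen. This puts 2,4-dichlorophenyl in place of 2,5-dimethylphenyl on a saturated chain carbon bound to an amide-type nitrogen.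

Within the data shown here, only one measured step bears on this change: a 4.5-fold lower number from compound 1 to compound 2 (0.66 log units; beyond the scatter). It brings in 2,5-dimethylphenyl in place of 4-methylphenyl on the same carbon, and it is a modest step beyond the scatter. Two compounds show that this assay responds to the substitution of this aryl group, but neither carries chlorine, so the data give no firm direction for the exchange. Given the modest size of the step of a 4.5-fold lower number from compound 1 to compound 2 (0.66 log units; beyond the scatter), the expected change is no larger than that, and probably no step beyond the scatter. The estimated step is a 1.4-fold higher number from compound 2 to compound 3 (0.13 log units; within the scatter). For compound 3 the estimated value is 15 nM, with an expected range of 5 nM to 45 nM.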

Compound 3, half-maximal inhibitory concentration: 165 nM
Beside the measured number, compound 3's estimate is 11-fold (1.04 log units) below it; measured number outside the range, above it.
By their numbers in this assay, from the lowest: compound 2; then compound 1; then compound 3.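

In this assay, within the data shown here, the aryl group on a saturated chain carbon bound to an amide-type nitrogen proves able to produce a large step (a 15-fold higher number from compound 2 to compound 3 (1.18 log units; beyond the scatter)), where the only earlier step at this position was modest. The 2,4-dichlorophenyl group also gives a weaker inhibitor than the 4-methylphenyl group (a 3.3-fold higher number from compound 1 to compound 3 (0.52 log units; beyond the scatter)), so the order runs compound 2, compound 1, compound 3, with a disubstituted aryl group at each end and the singly substituted one in the middle; having two substituents on the ring therefore does not by itself give the lower number. No supporting data on these compounds offer an explanation for the rise from the 2,5-dimethylphenyl to the 2,4-dichlorophenyl compound.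

Going by these compounds, the exchange alters both the kind of substituent and the substitution pattern at once, so the share of each in the step remains open. The 2,5-dichlorophenyl and 2,4-dimethylphenyl groups on the same carbon would separate the two, and an unsubstituted phenyl group would give a reference for all three aryl groups shown.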